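The source may report more compounds than this note shows. Statements on the series, on what has been measured and on what is new or still open speak of the compounds shown alone.

Compound 1 `COC(=O)c1nc(C)c2c(c1N)C(=O)N(Cc1ccccc1)C2=O` and compound 2 `CNC(=O)c1nc(C)c2c(c1N)C(=O)N(Cc1ccccc1)C2=O` share one core; in a physicochemical assay for solubility, using the shake flask method, in simulated intestinal fluid, measured as kinetic solubility, with a stated time of 2 h, at 25 degrees C, at pH 6.5 (on this read-out lower numbers stand for lower solubility and higher numbers for higher solubility), compound 1 gives 7400 nM and compound 2 gives 41000 nM, a step of a 5.5-fold higher number from compound 1 to compound 2 (0.74 log units; beyond the scatter). Compound 3 `Cc1noc(-c2nc(C)c3c(c2N)C(=O)N(Cc2ccc(C(F)(F)F)cc2)C3=O)n1` carries a different group on the nitrogen of the core. In this assay compound 3 reaches only a limit, < 5000 nM, as noted in the limit of < 5000 nM in this assay, at which 1 of the 3 values shown sits, so its true value is not known. Compound 4 `Cc1noc(-c2nc(C)c3c(c2N)C(=O)N(Cc2ccc(N(C)C)cc2)C3=O)n1` differs from compound 3 in one place: dimethylamino in place of trifluoromethyl on an aromatic carbon. Among the measured compounds shown here, no measured step touches this position, so the only guide is the size of the one measured step. The step of an at least 3.0-fold higher number from compound 3 to compound 4 (0.47 log units; beyond the scatter) is expected to be a modest rise. Compound 4 is expected to give about 15000 nM, with a range from 5000 nM to 60000 nM.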

Compound 4, solubility: 7400 nM
Beside the measured number, compound 4's estimate is 2.0-fold (0.31 log units) above it; measured number inside the range.
By their numbers in this assay, from the lowest: compounds 1 and 4 (each within the scatter of the next); then compound 2. At a limit, below all of these: compound 3.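

Among the compounds shown here, changing 4-(trifluoromethyl)phenyl to 4-(dimethylamino)phenyl gives the first reading at this position in this assay, with an at least 1.4-fold higher number from compound 3 to compound 4 (0.17 log units; that floor lies within the scatter). This step is only a floor that lies within the scatter, so the data do not fix its true size or show a real rise. Compound 3 stands at a limit and not at a number: the limit of < 5000 nM in this assay, at which 1 of the 4 values shown sits.

As far as these compounds go, what an amine or a carboxylic acid would give at this place on the phenyl ring remains open. Also open, from the compounds shown here alone, is how far the 4-(dimethylamino)phenyl group's reading would hold with other groups on the shared core.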